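Acetyl for methoxymethyl: working notes on the series

A few compounds are considered here, and "the series" means these few. Any claim that something is new, unique, unknown or untested is made for them only; others in the source may bear on it.

- Compound 1 `CCCn1c(=O)n(CCCO)c(=O)c2[nH]cnc21`: 5100 nM
- Compound 2 `CCCn1c(=O)n(CCOC)c(=O)c2[nH]cnc21`: 700 nM

In a functional assay (trachea) with Cavia porcellus as the target (on this read-out higher numbers stand for an effect only at larger amounts of compound and lower numbers for an effect already at smaller amounts), compound 2 gives 700 nM, the lower of the two numbers. Compound 3 `CCCn1c(=O)n(CC(C)=O)c(=O)c2[nH]cnc21` is next, with this change: acetyl in place of methoxymethyl on a saturated chain carbon bound to an aromatic nitrogen. In words, acetyl replaces methoxymethyl on a saturated chain carbon bound to an aromatic nitrogen. Among the measured compounds shown here, the only measured step, a 7.3-fold lower number from compound 1 to compound 2 (0.86 log units; beyond the scatter), is modest and concerns a different exchange, so it bears on this change only indirectly. For the measured compounds named here, the data offer no direct precedent for this exchange. The expected outcome is a 1.3-fold higher number from compound 2 to compound 3 (0.11 log units; within the scatter), so no shift beyond the scatter is anticipated. For compound 3 the estimate in this assay is 900 nM, with an expected range of 300 nM to 2700 nM.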

Compound 3, half-maximal effective concentration: 14900 nM
For compound 3 the middle estimate is 17-fold (1.22 log units) below the measured one, outside the stated range (above it).
By their numbers in this assay, from the lowest: compound 2; then compound 1; then compound 3.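

In this assay, the position separates groups that match in heavy atoms and hydrogen-bond acceptors: acetyl in place of methoxymethyl gives a 21-fold higher number from compound 2 to compound 3 (1.33 log units; beyond the scatter) on a saturated chain carbon bound to an aromatic nitrogen. Acetyl in place of 2-hydroxyethyl gives a 2.9-fold higher number from compound 1 to compound 3 (0.47 log units; beyond the scatter) and leaves compound 3 with the highest number of the three. Nothing available accounts for either step.

Open, on these data alone, is whether an amine, a carboxylic acid or a longer chain ending in methoxy at this position would stay near compound 2 or move toward compound 3.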